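Indol-2-yl replaces methylpyridinyl on a high-clearance core

The source may hold more compounds than are shown below. What is called first, only, known or untested is meant among the compounds shown, and "the series" means these compounds.

Three compounds share one core and differ only in the group on an aromatic carbon of the pyridine ring. Compound 1 `Nc1ccc(S(=O)(=O)N2CCN(c3ncc(C(O)(C(F)(F)F)C(F)(F)F)cc3C3CC3)CC2)cn1` carries cyclopropyl there, and in an ADME assay (liver) for metabolic stability, with Liver microsome (Rattus norvegicus) as the target, using microsomes and NADPH, with a stated time of 30 min, tested at 1 uM (a lower number here means slower removal, a higher number faster removal of the compound), compound 1 gives 27 mL.min-1.g-1. Compound 2 `Nc1ccc(S(=O)(=O)N2CCN(c3ncc(C(O)(C(F)(F)F)C(F)(F)F)cc3C#CCO)CC2)cn1` bears 3-hydroxyprop-1-yn-1-yl, and in this assay compound 2 gives 65 mL.min-1.g-1. Compound 3 `Cc1ccc(-c2cc(C(O)(C(F)(F)F)C(F)(F)F)cnc2N2CCN(S(=O)(=O)c3ccc(N)nc3)CC2)cn1` bears 6-methylpyridin-3-yl, and in this assay compound 3 gives 182 mL.min-1.g-1, the highest of the three numbers. The measured steps all run upward: a 2.4-fold higher number from compound 1 to compound 2 (0.38 log units; beyond the scatter), a 6.7-fold higher number from compound 1 to compound 3 (0.83 log units; beyond the scatter) and a 2.8-fold higher number from compound 2 to compound 3 (0.45 log units; beyond the scatter).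

Compound 4 `Nc1ccc(S(=O)(=O)N2CCN(c3ncc(C(O)(C(F)(F)F)C(F)(F)F)cc3-c3cc4ccccc4[nH]3)CC2)cn1` is not yet measured. The change from compound 3 is 1H-indol-2-yl in place of 6-methylpyridin-3-yl on an aromatic carbon. Every step so far that replaced a small group with an aromatic ring raised the number in this assay, as the step from compound 1 to compound 3 shows; the step from compound 3 to compound 4 replaces one aromatic ring with a larger one, for which no direct precedent is shown. The expectation is therefore a modest further rise or a number close to that of compound 3, expressed as a 1.4-fold higher number from compound 3 to compound 4 (0.15 log units; within the scatter). Compound 4 is estimated at 260 mL.min-1.g-1 in this assay, with a range from 120 mL.min-1.g-1 to 550 mL.min-1.g-1.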

Compound 4, intrinsic clearance in microsomes: 146 mL.min-1.g-1
Compound 4: middle estimate off by 1.8-fold (0.25 log units), on the high side; low and high end bracket the measured number.
By their numbers in this assay, from the lowest: compound 1; then compound 2; then compounds 4 and 3 (each within the scatter of the next).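

In this assay this position, on an aromatic carbon ortho to a large group, accepts the two-ring 1H-indol-2-yl in place of the single-ring 6-methylpyridin-3-yl with a 1.2-fold lower number from compound 3 to compound 4 (0.10 log units; within the scatter) and the two compounds cannot be told apart, even though the entering group brings a five-membered aromatic ring and a hydrogen-bond donor. The high numbers at this position are thus no longer tied to 6-methylpyridin-3-yl alone, as 1H-indol-2-yl also stands clear of the two non-aromatic groups, with a 2.2-fold higher number from compound 2 to compound 4 (0.35 log units; beyond the scatter) and with a 5.4-fold higher number from compound 1 to compound 4 (0.73 log units; beyond the scatter) as the wider step. No measurement at hand explains why these two aromatic groups give such similar numbers.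

The compounds shown leave open whether the hydrogen on the indole nitrogen plays any part, which 1-methylindol-2-yl at the same carbon would test. They also leave open whether any aromatic ring at this position gives a number this high, or whether a saturated ring such as piperidine, or an aromatic ring carrying a carboxylic acid or an amine, would give a lower one.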